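Tert-Butyl in Place of Cyclopentyl at the Ether Carbon

A few compounds are considered here, and "the series" means these few. Any claim that something is new, unique, unknown or untested is made for them only; others in the source may bear on it.

Measured so far:
compound 1 `O=C(O)CCNC(=O)c1ccc(C(Oc2ccc(-n3cc(C(F)(F)F)cn3)cc2)C2CC2)cc1` — 1300 nM
compound 2 `O=C(O)CCNC(=O)c1ccc(C(Oc2ccc(-n3cc(C(F)(F)F)cn3)cc2)C2CCCC2)cc1` — 420 nM

Both compounds share one core and differ only in the group on a saturated chain carbon bound to an aromatic carbon and an oxygen on an aromatic ring. In an assay on cells for displacement of a labelled ligand from Glucagon receptor (Homo sapiens), in the presence of a further agent that is not named here (a lower number here means a stronger inhibitor, a higher number a weaker inhibitor), compound 1 gives 1300 nM, and compound 2 gives 420 nM. The step of a 3.1-fold lower number from compound 1 to compound 2 (0.49 log units; beyond the scatter) shows that the larger ring helps, and compound 2 holds the lowest number of the two.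

Compound 3 `CC(C)(C)C(Oc1ccc(-n2cc(C(F)(F)F)cn2)cc1)c1ccc(C(=O)NCCC(=O)O)cc1` is not yet measured. Its change from compound 2 is tert-butyl in place of cyclopentyl on a saturated chain carbon bound to an aromatic carbon and an oxygen on an aromatic ring. Among the measured compounds shown here, the only step that bears on it is a 3.1-fold lower number from compound 1 to compound 2 (0.49 log units; beyond the scatter), where more carbon at this position lowered the number. Tert-butyl keeps a similar amount of carbon but loses the ring, so compound 3 is expected to land near compound 2, with a step of a 1.2-fold higher number from compound 2 to compound 3 (0.08 log units; within the scatter) that stays within the scatter. The estimate for compound 3 is 500 nM, with a range from 200 nM to 1500 nM.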

Compound 3, inhibition constant: 170 nM
Compound 3: the middle estimate sits 2.9-fold (0.47 log units) above what was measured; measured number below the stated range.
By their numbers in this assay, from the lowest: compound 3; then compound 2; then compound 1.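

In this assay, the step of a 2.5-fold lower number from compound 2 to compound 3 (0.39 log units; beyond the scatter) shows that a ring is not needed on this saturated chain carbon bound to an aromatic carbon and an oxygen on an aromatic ring. Tert-butyl, with 4 heavy atoms and no ring, gives a lower number than cyclopentyl, with 5 heavy atoms, so compound 3 goes against the simple reading of compounds 1 and 2 that more carbon here lowers the number. The full gain across these groups is a 7.6-fold lower number from compound 1 to compound 3 (0.88 log units; beyond the scatter) and no measurement shown here explains it.

Going by these compounds, it remains open whether other branched chains, such as isopropyl, would match tert-butyl at this carbon. A larger ring such as cyclohexyl, or a flat ring such as phenyl, could also land on either side of compound 3.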